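Stability of compound 3 after a side-chain change

The compounds below may be only part of what the source reports. "The series", "measured", "known", "first", "only" and "open" are said of these compounds alone.

- Compound 1 `COc1ccc(Nc2nc(Cl)cn([C@H](C)C3CC3)c2=O)c(OC)n1` in an ADME assay on microsomes from liver (Homo sapiens) for metabolic stability, with a stated time of 10 min; on this read-out lower numbers stand for a less stable compound and higher numbers for a more stable compound: 25%
- Compound 2 `COc1nc(C)c(Nc2nc(Cl)cn([C@H](C)C3CC3)c2=O)c(OC)n1` in this assay: 81%

Of the two measured numbers, compound 2 stands highest at 81%, and compound 1 lies lower at 25%, a gap beyond the scatter.

Compound 3 `COC[C@@H](C1CC1)n1cc(Cl)nc(Nc2c(C)nc(OC)nc2OC)c1=O` has the rest of compound 2 unchanged but carries 1-cyclopropyl-2-methoxyethyl in place of 1-cyclopropylethyl on an aromatic nitrogen.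

For the measured compounds named here, no measured step covers this change, so the expectation is loose and rests on the structural change alone. A small fall in this assay is expected, of a size near the usual scatter, with the estimated step of a number 9 percentage points lower from compound 2 to compound 3 (within the scatter).

For compound 3 the estimated value is 72%, with an expected range of 52% to 88%.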

Compound 3, percent of the compound remaining: 25%
Compound 3: the middle estimate sits 47 percentage points above what was measured, outside the stated range (below it).
By their numbers in this assay, from the lowest: compounds 1 and 3 (each within the scatter of the next); then compound 2.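

In this assay the group on the aromatic nitrogen proves to be a sensitive point in the series: 1-cyclopropyl-2-methoxyethyl in place of 1-cyclopropylethyl gives a large fall (a number 56 percentage points lower from compound 2 to compound 3 (beyond the scatter)). The earlier compounds shown here both carry 1-cyclopropylethyl, so they said nothing about this position, and this step shows that a change confined to this side chain can remove most of the stability of compound 2. No measured evidence bears on the reason for the size of this step.

The compounds shown do not separate the effect of the chain length from that of the ether oxygen; a 1-cyclopropylpropyl or 1-cyclopropyl-2-hydroxyethyl group on the same nitrogen would address this. On these data alone, whether the same step holds on the core of compound 1 also remains open.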